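A few compounds are considered here, and "the series" means these few. Any claim that something is new, unique, unknown or untested is made for them only; others in the source may bear on it.

Values in an ADME assay on MT4 cells (Homo sapiens) for cytotoxicity, with a stated time of 5 days; a lower number here means that less compound is tolerated, a higher number that more compound is tolerated:

- Compound 1 `CC1CC=C(C(=O)N(c2cc(C#CC(C)(C)C)sc2C(=O)O)C(C)C)CC1` gives > 20000 nM (a limit)
- Compound 2 `CC(C)(C)C#Cc1cc(N(C(=O)[C@H]2CC[C@H](C)CC2)[C@H]2CC[C@H](OC3COC3)CC2)c(C(=O)O)s1` gives > 20000 nM (a limit)
- Compound 3 `CC(C)N(c1cc(C#CC(C)(C)C)sc1C(=O)O)C(=O)[C@H]1CC[C@H](CF)CC1` gives > 20000 nM (a limit)

All three compounds share a single reading: the limit of > 20000 nM in this assay, at which 3 of the 3 values shown sit. In this assay compound 2 gives > 20000 nM, which is a limit of the assay and not a number. Its true position relative to the other compounds therefore cannot be read.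

Compound 4 `CC(C)(C)C#Cc1cc(N(C(=O)[C@H]2CC[C@H](C)CC2)[C@H]2CC[C@H](Oc3nccs3)CC2)c(C(=O)O)s1` keeps everything in compound 2 except one group: 1,3-thiazol-2-yl in place of oxetan-3-yl on an oxygen on a saturated carbon. In words, 1,3-thiazol-2-yl stands in place of oxetan-3-yl on an oxygen on a saturated carbon.

Going by the values given here, the one measured step, a step that the two limits leave unreadable from compound 1 to compound 3, is a change on a carbonyl carbon rather than on this oxygen. It has no readable size, so it offers no size to carry over. The expected result is a number no higher from compound 2 to compound 4 (the limit leaves the size open), which means no expected step beyond the usual scatter and no expected direction. Compound 4 is estimated at 20000 nM, with an expected range from 10000 nM to 40000 nM.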

Compound 4, half-maximal cytotoxic concentration: > 20000 nM
Compound 4 ended at the assay's limit; the forecaster's own chance of this, stated with the estimate: 70%; the middle value sits exactly at the limit.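

The step from compound 2 to compound 4 cannot be read, because both compounds give a limit of the assay and not a number: the limit of > 20000 nM in this assay, at which 4 of the 4 values shown sit.

The compounds shown leave open how much of any of them is truly tolerated in this assay, and whether 1,3-thiazol-2-yl and oxetan-3-yl differ there at all.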